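Swapping the group on an amide-type nitrogen

The source may report more compounds than this note shows. Statements on the series, on what has been measured and on what is new or still open speak of the compounds shown alone.

Measured in a functional assay on MCF7 cells (Homo sapiens) for antiproliferative activity, with a stated time of 72 h; a higher number here means that more compound is needed for the effect, a lower number that less compound is needed:
- compound 1 `O=C1OCc2cc(N(Cc3ccc(C4CCCCC4)cn3)C(=O)[C@H]3CCN3S(=O)(=O)c3c(F)c(F)c(F)c(F)c3F)ccc21`: 4600 nM
- compound 2 `CNC(=O)c1ccc(N(Cc2ccc(C3CCCCC3)cn2)C(=O)[C@H]2CCN2S(=O)(=O)c2c(F)c(F)c(F)c(F)c2F)cc1O`: 3800 nM
- compound 3 `Cn1ccc2cc(N(Cc3ccc(C4CCCCC4)cn3)C(=O)[C@H]3CCN3S(=O)(=O)c3c(F)c(F)c(F)c(F)c3F)ccc2c1=O`: 2800 nM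

Compound 3 gives 2800 nM, which lies within the scatter of the other two values. Compound 4 `O=C1NC(=O)c2cc(N(Cc3ccc(C4CCCCC4)cn3)C(=O)[C@H]3CCN3S(=O)(=O)c3c(F)c(F)c(F)c(F)c3F)ccc21` differs from compound 3 at the amide-type nitrogen: a group of 11 heavy atoms (8 carbon, 1 nitrogen, 2 oxygen; one five-membered non-aromatic ring with 1 hetero atom, one six-membered aromatic ring of carbon only) in place of a group of 12 heavy atoms (10 carbon, 1 nitrogen, 1 oxygen; one six-membered aromatic ring of carbon only, one six-membered aromatic ring with 1 hetero atom), on an amide-type nitrogen. The closest evidence comes from the earlier swaps at that same place: a 1.6-fold lower number from compound 1 to compound 3 (0.22 log units; within the scatter), a 1.4-fold lower number from compound 2 to compound 3 (0.13 log units; within the scatter) and a 1.2-fold lower number from compound 1 to compound 2 (0.08 log units; within the scatter). Each of these stayed within the scatter, so no step beyond the scatter is expected in this assay, in either direction. The expected change amounts to a 1.3-fold higher number from compound 3 to compound 4 (0.10 log units; within the scatter). Compound 4 is estimated at 3500 nM, with an expected range of 1500 nM to 8000 nM.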

Compound 4, half-maximal effective concentration: 7000 nM
For compound 4 the middle estimate is 2.0-fold (0.30 log units) below the measured one; measured number inside the range.
By their numbers in this assay, from the lowest: compounds 3, 2, 1 and 4 (each within the scatter of the next, the first and the last beyond it).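

In this assay, this place on the amide-type nitrogen now gives its first step beyond the scatter, though a modest one (a 2.5-fold higher number from compound 3 to compound 4 (0.40 log units; beyond the scatter)). The entering group stays within the scatter of the other two groups (a 1.8-fold higher number from compound 2 to compound 4 (0.27 log units; within the scatter); a 1.5-fold higher number from compound 1 to compound 4 (0.18 log units; within the scatter)), so only compound 3 separates from it. Nothing measured here accounts for this step.

The compounds shown leave open whether the hydrogen-bond donor of the entering group matters; a methyl group on its nitrogen would test that. They also leave open how a carboxylic acid or an amine at this place would compare.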